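Toward compound 4: tolerance expectations from three analogues

The source may report more compounds than this note shows. Statements on the series, on what has been measured and on what is new or still open speak of the compounds shown alone.

Compound 1 `CCC1(Cc2ccccc2)OS(=O)(=O)C=C1OCCCCc1ccccc1` stands in an ADME assay on HEL cells (Homo sapiens) for cytotoxicity, with a stated time of 3 days (a lower number here means that less compound is tolerated, a higher number that more compound is tolerated), only at a limit, >= 20000 nM. Compound 2 `CCC1(Cc2ccccc2)OS(=O)(=O)C=C1OCCCc1ccccc1` also reaches only a limit in this assay, >= 20000 nM. Compound 3 `CCC1(Cc2ccccc2)OS(=O)(=O)C=C1OCc1ccc(Br)cc1` gives a number in this assay, 80000 nM. The steps a step that the two limits leave unreadable from compound 1 to compound 2, a step that the limit leaves unreadable from compound 1 to compound 3 and a step that the limit leaves unreadable from compound 2 to compound 3 cannot be sized because the limit of >= 20000 nM in this assay, at which 2 of the 3 values shown sit, hides the true values of two compounds.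

Compound 4 `CCC1(Cc2ccccc2)OS(=O)(=O)C=C1OCc1ccc(C)cc1` differs from compound 1 by 4-methylphenyl in place of 3-phenylpropyl on a saturated chain carbon bound to an oxygen on an unsaturated carbon. Within the data shown here, none of the measured steps is readable, so no direction beyond scatter can be set; the nearest guide is compound 3, whose 4-bromophenyl analogue gave 80000 nM, and compound 4 is expected to be tolerated about as well. Compound 4 is estimated at 60000 nM, between 20000 nM and 200000 nM. The expected step is a step that the limit leaves unreadable from compound 1 to compound 4.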

Compound 4, minimum cytotoxic concentration: >= 16000 nM
Compound 4: no number, only a limit; the forecaster's own chance of this, stated with the estimate: 35%; the middle value lies beyond the limit too.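

The steps joining compound 4 to compound 1, compound 2 and compound 3 in this assay cannot be read because compound 4 gives only a limit: the limit of >= 16000 nM in this assay, at which 1 of the 4 values shown sits. Still open, as far as these compounds go, is whether these compounds differ in tolerance at all.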